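This account rests on a few compounds, and the source may have more. Where it says the series, first, only, none or still open, it means among the compounds named here.

In an assay for binding affinity to 5-hydroxytryptamine receptor 1F (Homo sapiens), read by radioligand binding (on this read-out lower numbers stand for stronger inhibition and higher numbers for weaker inhibition), compound 1 `CCCCCCCC(=O)Nc1ccc2[nH]cc(C3CCN(C)CC3)c2n1` gives 20 nM, and compound 2 `CN1CCC(c2c[nH]c3ccc(NC(=O)C4CC4)nc23)CC1` gives 9.8 nM. Among the compounds with values here, the one measured step, a 2.0-fold lower number from compound 1 to compound 2 (0.31 log units; beyond the scatter), leaves compound 2 with the lower of the two numbers. Compound 3 `COc1ccccc1C(=O)Nc1ccc2[nH]cc(C3CCN(C)CC3)c2n1` differs from compound 2 by 2-methoxyphenyl in place of cyclopropyl on a carbonyl carbon. That earlier step was modest and concerned a chain giving way to a small ring at the same carbonyl carbon, so it offers only loose guidance for an aromatic group entering there. Compound 3 is therefore expected to show a 2.6-fold higher number from compound 2 to compound 3 (0.41 log units; beyond the scatter), a small rise that may not clear the scatter. Compound 3 is estimated at 25 nM, within a range from 5 nM to 120 nM.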

Compound 3, inhibition constant: 20 nM
Beside the measured number, compound 3's estimate is 1.3-fold (0.10 log units) above it; measured number inside the range.
By their numbers in this assay, from the lowest: compound 2; then compounds 1 and 3 (each within the scatter of the next).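

Replacing cyclopropyl with 2-methoxyphenyl on the carbonyl carbon gives a 2.0-fold higher number from compound 2 to compound 3 (0.31 log units; beyond the scatter) and shows that this position tolerates an aromatic ring with only a modest loss. Replacing heptyl with the same ring gives no change at the digits printed from compound 1 to compound 3 (within the scatter) and leaves the aromatic group and the long chain level, with compound 2 still holding the lowest number of the three. Nothing available here accounts for these steps.

On these data alone, it remains open whether a plain phenyl without the methoxy group would read the same as 2-methoxyphenyl. As far as these compounds go, the effect of an amine or a carboxylic acid at this carbonyl carbon also remains open.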